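The compounds below may be only part of what the source reports. "The series", "measured", "known", "first", "only" and "open" are said of these compounds alone.

Three compounds have been measured in an assay on isolated protein for binding affinity to Alpha-1D adrenergic receptor (Rattus norvegicus), read by radioligand binding; on this read-out higher numbers stand for weaker inhibition and lower numbers for stronger inhibition:
compound 1, `CN(c1cccc2c1CCCC2c1c[nH]cn1)S(C)(=O)=O`: compound 1 gives 708 nM;
compound 2, `O=S(=O)(Nc1cccc2c1CCCC2c1c[nH]cn1)C1CC1`: compound 2 gives 2690 nM;
compound 3, `O=S(=O)(Nc1cccc2c1CCCC2c1c[nH]cn1)c1ccc2ccccc2c1`: compound 3 gives 100 nM.

Among these three numbers compound 2 stands highest in this assay. Its nearest neighbour is compound 1, whose number is lower by a step beyond the scatter, and the furthest is compound 3, whose number is lower still. Among the compounds with values here, only one step between neighbours is in hand: a 3.8-fold higher number from compound 1 to compound 2 (0.58 log units; beyond the scatter), a change that keeps a sulfonyl group on the ring nitrogen and alters what hangs from it.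

Compound 4, `O=C(Nc1cccc2c1CCCC2c1c[nH]cn1)C(F)(F)F`, departs from compound 2 by (trifluoromethyl)carbonyl in place of cyclopropylsulfonyl on a nitrogen on an aromatic ring. Within the data shown here, no measured step covers a sulfonyl exchanged for a carbonyl on that nitrogen; the one step available, from compound 1 to compound 2, does not speak to it, and compound 3 differs from compound 2 only within the sulfonyl series. The groups that leave and enter are of the same heavy-atom count, so the expectation rests mainly on compound 2 itself, with wide margins.

In this assay compound 4 is therefore expected to give about 1800 nM, with a range from 350 nM to 8000 nM. The step this estimate implies is expected to be a 1.5-fold lower number from compound 2 to compound 4 (0.17 log units; within the scatter).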

Compound 4, inhibition constant: 3310 nM
Compound 4: middle estimate off by 1.8-fold (0.26 log units), on the low side, within the range that was stated.
By their numbers in this assay, from the lowest: compound 3; then compound 1; then compounds 2 and 4 (each within the scatter of the next).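

Within the data shown here, compound 4 gives the first reading of a carbonyl in place of a sulfonyl on the nitrogen on an aromatic ring: in this assay, the exchange of cyclopropylsulfonyl for (trifluoromethyl)carbonyl amounts to a 1.2-fold higher number from compound 2 to compound 4 (0.09 log units; within the scatter), so the two groups cannot be told apart at this place. Set against compound 1, the ((trifluoromethyl)carbonyl)amino group gives a 4.7-fold higher number from compound 1 to compound 4 (0.67 log units; beyond the scatter), a step of the same modest order as a 3.8-fold higher number from compound 1 to compound 2 (0.58 log units; beyond the scatter), so compounds 2 and 4, which both keep the hydrogen on that nitrogen, share a number above that of compound 1, though compound 3, which keeps that hydrogen too, goes against any such pattern with 100 nM in the same assay. No other information bears on why the sulfonyl and the carbonyl read alike here.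

The compounds shown leave open whether an acetyl group, with hydrogen in place of the three fluorines, would read like the (trifluoromethyl)carbonyl group on this nitrogen. They also leave open what a methyl on the nitrogen of compound 4 would do, and whether a larger carbonyl group, such as benzoyl, would follow the number of compound 3.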